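A few compounds are considered here, and "the series" means these few. Any claim that something is new, unique, unknown or untested is made for them only; others in the source may bear on it.

Measured so far:
- compound 1, `c1ccc2c(NC3CCCCCC3)nc(N3CCC(N4CCCC4)CC3)nc2c1`: 10%
- compound 2, `COc1cc2nc(NCCN3CCCCC3)nc(NC3CCCCCC3)c2cc1OC`: 1%

Of the compounds shown here, two have been tested in an in vitro functional assay on B300-19 cells for antagonist activity at C-C chemokine receptor type 4 (Homo sapiens), read by GTPgammaS binding, tested at 1 uM; on this read-out higher numbers stand for more inhibition at the one concentration tested (going by the name of the read-out) and lower numbers for less inhibition. Compound 1, with the structure `c1ccc2c(NC3CCCCCC3)nc(N3CCC(N4CCCC4)CC3)nc2c1`, gives 10%. Compound 2, with the structure `COc1cc2nc(NCCN3CCCCC3)nc(NC3CCCCCC3)c2cc1OC`, gives 1%. Compound 2 carries the smaller of the two numbers, but its gap to compound 1 lies within the usual scatter of repeated measurements, so the two compounds cannot be told apart on this read-out; both sit at the low end of what the read-out can show.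

Compound 3, with the structure `COc1cc2nc(NCc3cccs3)nc(NC3CCCCCC3)c2cc1OC`, has not yet been measured in this assay. It differs from compound 2 in one place: thiophen-2-yl in place of (piperidin-1-yl)methyl on a saturated chain carbon bound to a nitrogen on an aromatic ring. For the measured compounds named here, no step between measured compounds covers a change of this kind, so there is nothing in the data from which a direction could be read. Starting from the low number of compound 2, given as 1%, the step from compound 2 to compound 3 is expected to be small, a number 5 percentage points higher from compound 2 to compound 3 (within the scatter), and not beyond the scatter in either direction. Compound 3 is therefore estimated to give 6% in this assay, within a range from -10% to 22%.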

Compound 3, a percentage reported as inhibition, at one concentration (the size of the read-out at that concentration, not a potency): 0%
Compound 3: the middle estimate sits 6 percentage points above what was measured, within the range that was stated.
By their numbers in this assay, from the lowest: compounds 3, 2 and 1 (each within the scatter of the next).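

In this assay, for the compounds shown here, thiophen-2-yl in place of (piperidin-1-yl)methyl on a saturated chain carbon bound to a nitrogen on an aromatic ring gives a number 1 percentage points lower from compound 2 to compound 3 (within the scatter), the first step at this position, and it does not separate the two groups. A six-membered non-aromatic ring with 1 hetero atom and a five-membered aromatic ring with 1 hetero atom thus cannot be told apart here at the one concentration tested, although both compounds sit at the low end of the read-out, so this flat step says little about how much the position matters. Nothing available explains this result.

From the compounds shown here alone, it remains open whether any other group at this position, such as a morpholine, a carboxylic acid or a longer chain ending in an amine, would move the number beyond the scatter. Going by these compounds, it is equally open whether the exchange of these two groups would stay this small on a compound whose number lies well above the low end of the read-out.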